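The compounds below may be only part of what the source reports. "The series", "measured", "known", "first", "only" and "open" are said of these compounds alone.

Series notes. Compound 1 `COc1ccc(/C=C/c2cc(OC)cc(OC)c2/C=C/C(=O)c2ccc(Br)cc2)cc1` and compound 2 `COc1ccc(/C=C/c2cc(OC)cc(OC)c2/C=C/C(=O)c2ccc(F)cc2)cc1` share one core and differ in a single place. In a functional assay on A549 cells (Homo sapiens) for antiproliferative activity, read by MTT assay, with a stated time of 48 h (a lower number here means a stronger inhibitor, a higher number a weaker inhibitor), compound 1 gives 8.3 ug/mL, and compound 2 gives 6.6 ug/mL. Among the measured compounds shown here, the only measured step is a 1.3-fold lower number from compound 1 to compound 2 (0.10 log units; within the scatter). On the numbers shown compound 2 stands lowest of the two, with compound 1 nearest; the two lie within the scatter of each other, so no order between them is claimed.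

Compound 3 `CCN(CC)c1ccc(C(=O)/C=C/c2c(/C=C/c3ccc(OC)cc3)cc(OC)cc2OC)cc1` is not yet measured. Relative to compound 2 the difference is diethylamino in place of fluoro on an aromatic carbon. For the measured compounds named here, no measured step covers this exchange; the one step so far, a 1.3-fold lower number from compound 1 to compound 2 (0.10 log units; within the scatter), swapped one halogen for another and stayed within the scatter, so it offers little guidance. For compound 3 in this assay the expected step is therefore a 1.1-fold lower number from compound 2 to compound 3 (0.04 log units; within the scatter), not beyond the scatter. Compound 3 is estimated at 6 ug/mL, with a range of 2.5 ug/mL to 14 ug/mL.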

Compound 3, half-maximal inhibitory concentration: 5.4 ug/mL
Estimate against measurement, compound 3: 1.1-fold (0.05 log units) above, and the stated range covers the measured number.
By their numbers in this assay, from the lowest: compounds 3, 2 and 1 (each within the scatter of the next).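

Until now this position had carried only halogens; with diethylamino, which brings 5 heavy atoms and 1 hydrogen-bond acceptor, in place of fluoro on the 4-fluorophenyl ring, the result in this assay shows no readable change (a 1.2-fold lower number from compound 2 to compound 3 (0.09 log units; within the scatter)). The exchange for bromo reads the same way (a 1.5-fold lower number from compound 1 to compound 3 (0.19 log units; within the scatter)), so a halogen and a much larger amino group cannot be told apart at this position in this assay. No measurement at hand explains this lack of separation.

As far as these compounds go, whether a carboxylic acid, a primary amine or a longer chain at this position would move the number beyond the scatter remains open. Since the three compounds vary in this one position only, they also say nothing about the methoxy groups or the rest of the shared core.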